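Methoxy in place of hydrogen: from compound 2 to compound 4

The source may report more compounds than this note shows. Statements on the series, on what has been measured and on what is new or still open speak of the compounds shown alone.

Measured so far:
compound 1 `COc1cc(/C=C/c2nc3cccnc3n(CC(=O)O)c2=O)ccc1O` — 85.5% in a functional assay, read by spectrophotometry, with a stated time of 30 min, tested at 100 uM; on this read-out higher numbers stand for a stronger effect at the one concentration tested and lower numbers for a weaker effect
compound 3 `COc1cc(/C=C/c2nc3cc(Cl)cnc3n(CC(=O)O)c2=O)ccc1O` — 94.9%
compound 2 `COc1cc(O)cc(-c2nc3cccnc3n(CC(=O)O)c2=O)c1` — "not determined" (no result reported)

For the measured compounds named here, the only measured step is a number 9.4 percentage points higher from compound 1 to compound 3 (within the scatter). Going by the values given here, compound 2 has no number, so it stands nowhere on this scale and no step from it can be sized. Compound 4 `COc1cc(-c2nc3cccnc3n(CC(=O)O)c2=O)cc(O)c1OC` differs from compound 2 by methoxy in place of hydrogen on an aromatic carbon. The step from compound 1 to compound 3 concerns a different change and does not bear on this one; no expectation of size or direction can be drawn from it. Compound 4 is therefore expected to give about 70%, estimated between 35% and 100%, the range wide for want of any anchor from compound 2.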

Compound 4, a percentage reported as activity, at one concentration (the size of the read-out at that concentration, not a potency): 20.5%
Beside the measured number, compound 4's estimate is 49.5 percentage points above it, outside the stated range (below it).
By their numbers in this assay, from the lowest: compound 4; then compounds 1 and 3 (each within the scatter of the next).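

Compound 2 has no number in this assay and so the step to compound 4 cannot be read. On these data alone, what methoxy in place of hydrogen does to this read-out stays open. Nothing shown bears on a cause for the result of compound 4.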